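The source may report more compounds than this note shows. Statements on the series, on what has been measured and on what is new or still open speak of the compounds shown alone.

Working notes on the series. Among the measured compounds shown here, compound 1 `O=C(Nc1ccccc1O)C1CCc2ccccc2N1C(=O)c1ccccc1Cl` is the only member of the set that returns a number rather than a limit: in a functional assay on NCI-H23 cells (Homo sapiens) for cytotoxicity, read by sulforhodamine B assay, with a stated time of 72 h (a higher number here means a weaker inhibitor of growth, a lower number a stronger inhibitor of growth), compound 1 gives 46900 nM. Compound 2 `O=C(Nc1ccccc1C(F)(F)F)c1ccc2ccccc2n1` carries a related anilide on a different core, and in this assay compound 2 gives > 90000 nM, which is a limit of the assay and not a number (the limit of > 90000 nM in this assay, at which 1 of the 3 values shown sits). Compound 3 `CCCC(=O)N1c2ccccc2CCC1C(=O)Nc1ccccc1C(F)(F)F` shares the core of compound 1 but differs in both appendages, and in this assay compound 3 gives > 70000 nM, again a limit rather than a number (the limit of > 70000 nM in this assay, at which 1 of the 3 values shown sits). For the measured compounds named here, no pair of measured compounds differs in a single place, so no measured step is available to anchor the change considered next.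

Compound 4 `O=C(Nc1ccccc1O)C1CCc2ccccc2N1` is compound 1 with hydrogen in place of (2-chlorophenyl)carbonyl on a nitrogen on an aromatic ring in a ring. Going by the values given here, with the only number in the set sitting close to the two limits, any further loss of growth inhibition would be likely to vanish into a limit. The step from compound 1 to compound 4 is estimated at a 1.7-fold higher number from compound 1 to compound 4 (0.23 log units; within the scatter), toward weaker growth inhibition, though a result within the scatter would not surprise. Compound 4 is expected to give 80000 nM, within 30000 nM to 200000 nM, with a substantial chance that only a limit is reported.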

Compound 4, concentration for 50% growth inhibition: 2230 nM
The estimate for compound 4 lay 36-fold (1.55 log units) above the measured number; measured number outside the range, below it.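

Hydrogen in place of (2-chlorophenyl)carbonyl on a nitrogen on an aromatic ring in a ring is the first single change that can be read in this assay, and it gives a 21-fold lower number from compound 1 to compound 4 (1.32 log units; beyond the scatter), toward stronger growth inhibition. The earlier compounds shown here differ from one another in more than one place and could not isolate this position; this pair shows that, with the rest of compound 1 unchanged, the (2-chlorophenyl)carbonyl group is not required for growth inhibition and that its removal improves the number. Nothing shown accounts for the size of this step.

Going by these compounds, it remains open whether the gain requires hydrogen on that nitrogen or only the loss of this particular group, a question that a small acetyl or methyl group at the same position would help to separate. On these data alone, it also remains open whether the step carries over to another anilide, such as the trifluoromethyl-bearing anilide of compound 3, which here occurs only together with a butanoyl group on the nitrogen.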